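The source may hold more compounds than are shown below. What is called first, only, known or untested is meant among the compounds shown, and "the series" means these compounds.

Series notes. Compound 2 `Cc1cc(C)cc(C(=O)NCN2CCC(c3cccc[n+]3[O-])CC2)c1` stands second highest of the three numbers in a functional assay on HEK293 cells for agonist activity at D(4) dopamine receptor (Homo sapiens), read by FLIPR (a lower number here means that less compound is needed, a higher number that more compound is needed for the effect), where compound 2 gives 90 nM; compound 3 `c1ccc(C2CCN(Cc3nc4ccccc4[nH]3)CC2)nc1` gives 12 nM and compound 1 `N#Cc1cccc(C(=O)NCN2CCC(c3cccc[n+]3[O-])CC2)c1` gives 840 nM. Compound 4 `O=C(NCN1CCC(c2cccc[n+]2[O-])CC1)c1ccccn1` is not yet measured; its change from compound 2 is pyridin-2-yl in place of 3,5-dimethylphenyl on a carbonyl carbon. Within the data shown here, the only measured step that bears on the group on the carbonyl carbon is a 9.3-fold lower number from compound 1 to compound 2 (0.97 log units; beyond the scatter), a change well beyond the scatter. Compound 3 carries no such group and does not inform this step. With a ring bearing a hetero atom entering in place of the ring of carbon only, compound 4 is expected to give a higher number, a step of a 3.3-fold higher number from compound 2 to compound 4 (0.52 log units; beyond the scatter). The estimate for compound 4 is 300 nM, with a range from 100 nM to 900 nM.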

Compound 4, half-maximal effective concentration: 3150 nM
For compound 4 the middle estimate is 11-fold (1.02 log units) below the measured one, outside the stated range (above it).
By their numbers in this assay, from the lowest: compound 3; then compound 2; then compound 1; then compound 4.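

In this assay the group on the carbonyl carbon matters more than the earlier pair showed: pyridin-2-yl gives a 35-fold higher number from compound 2 to compound 4 (1.54 log units; beyond the scatter) and a 3.8-fold higher number from compound 1 to compound 4 (0.57 log units; beyond the scatter), so it falls behind both substituted phenyl groups. Of the three groups, the only ring with a hetero atom gives the highest number, although three compounds establish no trend. Nothing measured here explains these steps.

Compound 4 both gains a ring nitrogen and loses the methyl groups of compound 2, and the step does not separate these changes. Unsubstituted phenyl on the carbonyl carbon would bear directly on that question.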